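Changing the Aromatic Group on a Carbonyl Carbon

A few compounds are considered here, and "the series" means these few. Any claim that something is new, unique, unknown or untested is made for them only; others in the source may bear on it.

Three measured compounds share one core and differ in the aromatic group on a carbonyl carbon. In a functional assay on a cell-free system (Platelet, plasma, Homo sapiens) for inhibition (a lower number here means a stronger inhibitor, a higher number a weaker inhibitor), compound 1 `Cc1ccc(N(CCN2CCC(OCC(=O)O)CC2)C(=O)c2ccc(F)cc2)cc1` gives 970 nM. In the same test, compound 2 `Cc1ccc(N(CCN2CCC(OCC(=O)O)CC2)C(=O)c2ccc(Cl)cc2)cc1` gives 690 nM, and the two differ by a 1.4-fold lower number from compound 1 to compound 2 (0.15 log units; within the scatter). Compound 3 `Cc1ccc(N(CCN2CCC(OCC(=O)O)CC2)C(=O)c2cccc(C)c2)cc1` has the lowest number of the three, at 160 nM.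

Compound 4 `COc1cc(OC)cc(C(=O)N(CCN2CCC(OCC(=O)O)CC2)c2ccc(C)cc2)c1` has not yet been measured. It carries 3,5-dimethoxyphenyl in place of 3-methylphenyl on a carbonyl carbon.

Two measured steps change the group at this place: a 6.1-fold lower number from compound 1 to compound 3 (0.78 log units; beyond the scatter) and a 4.3-fold lower number from compound 2 to compound 3 (0.63 log units; beyond the scatter). Both show 3-methylphenyl giving a lower number than the halogen-bearing groups, but neither involves a methoxy group, so they guide the new step only loosely. With so little evidence, no step beyond the scatter is expected, with a slight lean towards a higher number. The estimated change is a 1.3-fold higher number from compound 3 to compound 4 (0.10 log units; within the scatter). For compound 4 the expected value is 200 nM, with an estimated range of 60 nM to 700 nM.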

Compound 4, half-maximal inhibitory concentration: 530 nM
Compound 4: middle estimate off by 2.7-fold (0.42 log units), on the low side; the measured number falls inside the stated range.
By their numbers in this assay, from the lowest: compound 3; then compounds 4, 2 and 1 (each within the scatter of the next).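

In this assay, putting 3,5-dimethoxyphenyl in place of 3-methylphenyl on the carbonyl carbon raises the number (a 3.3-fold higher number from compound 3 to compound 4 (0.52 log units; beyond the scatter)), so the low value of compound 3 does not extend to every aromatic group without a halogen. The 3,5-dimethoxyphenyl group also cannot be told apart from the groups bearing chlorine (a 1.3-fold lower number from compound 2 to compound 4 (0.11 log units; within the scatter)) or fluorine (a 1.8-fold lower number from compound 1 to compound 4 (0.26 log units; within the scatter)), which leaves compound 3 as the strongest of the four. No measurement here speaks to the reason for these differences.

On these data alone, it remains open whether a plain phenyl group with no substituent, or a phenyl carrying an ethyl group or a single methoxy group, would match compound 3 (160 nM). Also open, as far as these compounds go, is whether 3-methylphenyl would keep its lead on a different core, as it appears here on only one.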